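The compounds below may be only part of what the source reports. "The series", "measured", "known", "first", "only" and "open" are said of these compounds alone.

Working notes on the series. Three compounds have numbers in an assay on isolated protein for binding affinity to leukotriene B4 receptor 1 (Homo sapiens), tested at 1 uM; a lower number here means less inhibition, a higher number more inhibition at the concentration tested (going by the name of the read-out): compound 1 `CCCCCCc1cc(C(C)=O)c(O)cc1OCCCCC#N` gives 13%, compound 2 `C=CCc1cc(C(C)=O)c(O)cc1OCC#N` gives 2%, and compound 3 `CCc1cc(C(C)=O)c(O)cc1OCCCC(C)(C)c1nnn[nH]1` gives 76%. Compound 2 stands lowest of the three; its nearest neighbour is compound 1, with a number higher by more than the scatter, and compound 3 lies furthest away, far higher.

Compound 4 `C=CCCCCOc1cc(O)c(C(C)=O)cc1CC=C` has not been measured. Its change from compound 2 is pent-4-en-1-yl in place of cyano on a saturated chain carbon bound to an oxygen on an aromatic ring. Going by the values given here, no measured pair isolates this change, so the only guidance is that compound 1, which also carries a longer chain on the ether oxygen and a longer chain on the core, sits above compound 2 by a margin beyond the scatter. A small rise is expected, a number 13 percentage points higher from compound 2 to compound 4 (beyond the scatter), in this assay. Compound 4 is therefore estimated at 15%, within 2% to 35%.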

Compound 4, a percentage reported as inhibition, at one concentration (the size of the read-out at that concentration, not a potency): 27%
The estimate for compound 4 lay 12 percentage points below the measured number; low and high end bracket the measured number.
By their numbers in this assay, from the lowest: compound 2; then compound 1; then compound 4; then compound 3.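

Going by these compounds alone, on the saturated chain carbon bound to an oxygen on an aromatic ring, pent-4-en-1-yl in place of cyano gives the first one-place comparison, and in this assay the step reads a number 25 percentage points higher from compound 2 to compound 4 (beyond the scatter). The entering group has no hydrogen-bond acceptor and the leaving group has one, so the acceptor of the cyano group is not needed at this position for the number to rise. Nothing measured speaks to the reason for the rise.

On these data alone, whether a carboxylic acid or an amine in place of pent-4-en-1-yl on that carbon would move the number further stays open. So does the effect of a longer chain there.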